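A few compounds are considered here, and "the series" means these few. Any claim that something is new, unique, unknown or untested is made for them only; others in the source may bear on it.

Measured so far in a functional assay on U-251 cells (Homo sapiens) for inhibition, read by sulforhodamine B assay, with a stated time of 48 h, tested at 10 uM; on this read-out lower numbers stand for less inhibition and higher numbers for more inhibition at the one concentration tested (going by the name of the read-out):
compound 1 `CCc1ccc(-c2cn3ccnc3c(-c3ccc4ncn(Cc5ccccc5)c4c3)n2)cc1` gives 46.1%;
compound 2 `O=Cc1ccc(-c2cn3ccnc3c(-c3ccc4ncn(Cc5ccccc5)c4c3)n2)cc1` gives 32%.

Compound 2 holds the lowest of the two numbers, and its nearest neighbour is compound 1. Among the measured compounds shown here, the single measured step, a number 14.1 percentage points lower from compound 1 to compound 2 (beyond the scatter), came with formyl in place of ethyl on an aromatic carbon, so swapping what sits on that aryl ring has so far moved the read-out only modestly.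

Compound 3 `c1ccc(Cn2cnc3ccc(-c4nc(-c5cccc6ccccc56)cn5ccnc45)cc32)cc1` differs from compound 2 by naphthalen-1-yl in place of 4-formylphenyl on an aromatic carbon. For the measured compounds named here, no measured step replaces the whole aryl ring with naphthalen-1-yl, so the one step bears on this change only indirectly: it shows the number can fall when a formyl group is introduced, and the group entering here carries no formyl. Compound 3 is therefore expected to shift by a number 10 percentage points higher from compound 2 to compound 3 (within the scatter), upward but not far beyond the scatter. In this assay compound 3 is estimated at 42%, with a range from 22% to 62%.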

Compound 3, a percentage reported as inhibition, at one concentration (the size of the read-out at that concentration, not a potency): 5.53%
Beside the measured number, compound 3's estimate is 36.5 percentage points above it; measured number below the stated range.
By their numbers in this assay, from the lowest: compound 3; then compound 2; then compound 1.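

In this assay, the aromatic carbon next to the ring nitrogen proves sensitive to the whole aryl group it carries: naphthalen-1-yl in place of 4-formylphenyl gives a number 26.5 percentage points lower from compound 2 to compound 3 (beyond the scatter), and in place of 4-ethylphenyl it gives a number 40.6 percentage points lower from compound 1 to compound 3 (beyond the scatter). The earlier compounds shown here showed only a change in the group on the phenyl ring, whereas this result shows that exchanging the ring itself for naphthalen-1-yl can take the number well below both phenyl compounds. Nothing available explains this fall.

The compounds shown leave open whether the fall follows from the second fused ring or from the point of attachment, which a naphthalen-2-yl group could separate. Going by these compounds, how a plain phenyl, or a phenyl carrying an amine or a carboxylic acid, would read at this position also remains open.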